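The source may hold more compounds than are shown below. What is called first, only, known or untested is meant among the compounds shown, and "the series" means these compounds.

Compound 1 `C[C@H]1CC[C@@H]2[C@@H](OC(=O)[C@]23CC(c2ccccc2Br)=NO3)[C@]2(C)C(=O)C=C[C@@]12O`: 18000 nM
Compound 2 `C[C@H]1CC[C@@H]2[C@@H](OC(=O)[C@]23CC(c2ccccc2)=NO3)[C@]2(C)C(=O)C=C[C@@]12O`: 39800 nM

In a functional assay on DU-145 cells (Homo sapiens) for cytotoxicity, read by sulforhodamine B assay, with a stated time of 48 h (on this read-out lower numbers stand for stronger inhibition and higher numbers for weaker inhibition), compound 2, at 39800 nM, holds the higher of the two numbers. Compound 3 `C[C@H]1CC[C@@H]2[C@@H](OC(=O)[C@]23CC(c2ccc(N(C)C)cc2)=NO3)[C@]2(C)C(=O)C=C[C@@]12O` differs from it by dimethylamino in place of hydrogen on an aromatic carbon, para to a large group. Among the compounds with values here, one measured step bears on this: a 2.2-fold higher number from compound 1 to compound 2 (0.34 log units; beyond the scatter), a modest one for hydrogen in place of bromo. Within the data shown here, no measurement yet covers dimethylamino, so a similarly modest lowering is only tentatively expected. The expected change is a 1.6-fold lower number from compound 2 to compound 3 (0.20 log units; within the scatter). Compound 3 is estimated at 25000 nM, with an expected range of 9000 nM to 70000 nM.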

Compound 3, half-maximal inhibitory concentration: 4500 nM
Estimate against measurement, compound 3: 5.6-fold (0.74 log units) above; measured number outside the range, below it.
By their numbers in this assay, from the lowest: compound 3; then compound 1; then compound 2.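

In this assay, dimethylamino on an aromatic carbon para to a large group gives an 8.8-fold lower number from compound 2 to compound 3 (0.95 log units; beyond the scatter), so this position responds to substitution by a step beyond the scatter. The change from 2-bromophenyl to 4-(dimethylamino)phenyl gives a 4.0-fold lower number from compound 1 to compound 3 (0.60 log units; beyond the scatter), leaving compound 3 with the lowest of the three numbers. Nothing available here accounts for either step.

The compounds shown leave open whether a primary amine or a methoxy group at this position would give a similar step. They also leave open whether a larger amine, such as diethylamino or morpholine, would keep it.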